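The source may report more compounds than this note shows. Statements on the series, on what has been measured and on what is new or still open speak of the compounds shown alone.

Compound 3 `CC1(C)c2[nH]nc(NC(=O)c3ccccc3)c2CN1Cc1ccc(F)cc1F` gives the highest of the three numbers in an assay on Sf21 cells for inhibition of high affinity nerve growth factor receptor (Homo sapiens), read by HTRF, with a stated time of 30 min, in the presence of a further agent that is not named here; on this read-out lower numbers stand for stronger inhibition and higher numbers for weaker inhibition: in this assay compound 3 gives 2320 nM. Compound 1 `COc1cccc(CN2Cc3c(NC(=O)c4ccccc4)n[nH]c3C2(C)C)c1` gives 1120 nM and compound 2 `CC1(C)c2[nH]nc(NC(=O)c3ccccc3)c2CN1Cc1ccc(F)cc1` gives 1180 nM. The measured steps all concern the aryl group on the saturated chain carbon bound to the amine nitrogen in the ring: a 1.1-fold higher number from compound 1 to compound 2 (0.02 log units; within the scatter), a 2.1-fold higher number from compound 1 to compound 3 (0.32 log units; beyond the scatter) and a 2.0-fold higher number from compound 2 to compound 3 (0.29 log units; within the scatter), so the largest change seen at this position was a modest one.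

Compound 4 `CC1(C)c2[nH]nc(NC(=O)c3ccccc3)c2CN1Cc1c(F)cccc1F` differs from compound 3 in the same place: 2,6-difluorophenyl in place of 2,4-difluorophenyl on a saturated chain carbon bound to an amine nitrogen in a ring. Among the compounds with values here, no measured step moves a fluorine from one aromatic carbon to another with the ring otherwise unchanged, so there is no direct precedent. Since every change at this aryl group, as in a 2.0-fold higher number from compound 2 to compound 3 (0.29 log units; within the scatter), stayed small, compound 4 is expected to give a number close to that of compound 3, with a step of a 1.0-fold lower number from compound 3 to compound 4 (0.00 log units; within the scatter) that is not expected to exceed the scatter. Compound 4 is therefore estimated at 2300 nM, within a range from 1000 nM to 5500 nM.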

Compound 4, half-maximal inhibitory concentration: 520 nM
The estimate for compound 4 lay 4.4-fold (0.65 log units) above the measured number, outside the stated range (below it).
By their numbers in this assay, from the lowest: compound 4; then compounds 1, 2 and 3 (each within the scatter of the next, the first and the last beyond it).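

In this assay the placement of the two fluorines alone proves to matter: with the same atoms in the group, 2,6-difluorophenyl in place of 2,4-difluorophenyl gives a 4.5-fold lower number from compound 3 to compound 4 (0.65 log units; beyond the scatter) and is the largest step seen at this position. Compound 4 also separates from the two compounds with one substituent on this aryl group, with a 2.3-fold lower number from compound 2 to compound 4 (0.36 log units; beyond the scatter) and with a 2.2-fold lower number from compound 1 to compound 4 (0.33 log units; beyond the scatter), so it gives the lowest number of the four. Nothing given here accounts for this effect of the fluorine placement.

The compounds shown leave open whether the lower number needs both fluorines, as a 2-fluorophenyl group would show, or whether 2,6-dichlorophenyl or 2,6-dimethylphenyl would serve as well. They also leave open whether the step would persist with an amine added elsewhere on the shared core.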